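The source may report more compounds than this note shows. Statements on the series, on what has been measured and on what is new or still open speak of the compounds shown alone.

Working notes on the series, all values from a functional assay on MRC5 cells (Homo sapiens) for inhibition, read by microscopy and resazurin assay, with a stated time of 72 h; on this read-out higher numbers stand for weaker inhibition and lower numbers for stronger inhibition.

Compound 1 `C=CCONC(=O)CN1C(=O)S/C(=C\c2cccc(C(=O)N[C@@H](CC(C)C)C(=O)OC)c2)C1=O`: > 128000 nM, a limit of this assay.
Compound 2 `C=CCONC(=O)CN1C(=O)S/C(=C\c2cccc(C(=O)N[C@H](C(=O)OC)C(C)C)c2)C1=O`: > 128000 nM, a limit of this assay.
Compound 3 `CC(C)[C@H](NC(=O)[C@H](C)NC(=O)c1cn(CC(=O)NOCc2ccccc2)c2ccccc12)C(=O)O`: > 128000 nM, a limit of this assay.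

Compound 2 and compound 1 share a core and differ by isobutyl in place of isopropyl on a saturated chain carbon bound to an amide-type nitrogen and a carbonyl carbon. The step that the two limits leave unreadable from compound 2 to compound 1 cannot be sized, because of the limit of > 128000 nM in this assay, at which 3 of the 3 values shown sit; both values are limits and no number is known for either.

Compound 3 has a different core from compound 2; the difference between the two cores is not broken down here. In this assay compound 3 gives > 128000 nM, again a limit.

Compound 4 `CC(C)C[C@H](NC(=O)[C@H](C)NC(=O)c1cn(CC(=O)NOCc2ccccc2)c2ccccc12)C(=O)O` is not yet measured. It is made from compound 3 by isobutyl in place of isopropyl on a saturated chain carbon bound to an amide-type nitrogen and a carbonyl carbon, the same change as from compound 2 to compound 1, at the same place. Since that earlier step gave only two limits, no size can be carried over. The step from compound 3 to compound 4 is expected to be a step that the limit leaves unreadable from compound 3 to compound 4, resting only on compound 3 sitting at > 128000 nM. Compound 4 is therefore expected at 200000 nM, most likely again reported as a limit.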

Compound 4, half-maximal inhibitory concentration: > 128000 nM
Compound 4: no number, only a limit; the forecaster's own chance of this, stated with the estimate: 90%; the middle value is on the limit's open side.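

No new step can be read: compound 3 and compound 4 stand only as limits, so the change between them has no size, and the same holds for compound 2 and compound 1: the limit of > 128000 nM in this assay, at which 4 of the 4 values shown sit.

The compounds shown leave open what number any of the four would give, and whether isobutyl in place of isopropyl changes inhibition on either core.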